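A Methyl Added Beside a Value Sitting at the Limit

This account rests on a few compounds, and the source may have more. Where it says the series, first, only, none or still open, it means among the compounds named here.

Compound 1 `Cc1nc(C)c(-c2nn(-c3ccc(F)cc3)cc2/C=C/C(=O)c2c(O)cc(C)c(Cl)c2C)s1` was tested in an ADME assay on A549 cells (Homo sapiens) for inhibition, read by MTT assay (on this read-out lower numbers stand for stronger inhibition of growth and higher numbers for weaker inhibition of growth), and compound 1 gives 33.5 ug/mL. Compound 2 `Cc1nc(C)c(-c2nn(-c3ccc(F)cc3)cc2C2CC(c3cc(Cl)ccc3O)=NN2)s1` in this assay gives only > 250 ug/mL, which is a limit of the measurement and not a number. Compound 2 thus stands at the limit of > 250 ug/mL in this assay, at which 1 of the 2 values shown sits. Compound 3 `Cc1nc(C)c(-c2nn(-c3ccc(F)cc3)cc2C2CC(c3cc(Cl)c(C)cc3O)=NN2)s1` differs from compound 2 by methyl in place of hydrogen on an aromatic carbon. Among the measured compounds shown here, no measured step connects the two. The expected step is a number no higher from compound 2 to compound 3 (the limit leaves the size open), none beyond the usual scatter. Compound 3 is therefore estimated at 250 ug/mL, within 120 ug/mL to 600 ug/mL.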

Compound 3, concentration for 50% growth inhibition: 146 ug/mL
For compound 3 the middle estimate is 1.7-fold (0.23 log units) above the measured one; the measured number falls inside the stated range.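

In this assay, replacing hydrogen with methyl on this aromatic carbon gives an at least 1.7-fold lower number from compound 2 to compound 3 (0.23 log units; that floor lies within the scatter). With the methyl ortho to the chloro group and meta to the hydroxy group, compound 3 gives a measured number, 146 ug/mL. The value for compound 2 is only a limit, so the true size of the step stays unknown: the limit of > 250 ug/mL in this assay, at which 1 of the 3 values shown sits.

The compounds shown leave open whether an ethyl group, a methoxy group or an amine at this place would move the number further. They also leave open how methyl would act on another carbon of this ring.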